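Methylation of a Phenol on a Second Core

The source may hold more compounds than are shown below. What is called first, only, known or untested is meant among the compounds shown, and "the series" means these compounds.

Compound 1, `O=C(Nc1cccc(-n2cc(-c3ccncc3)c(-c3cc(O)cc(Cl)c3)n2)c1)Nc1ccc(Cl)c(C(F)(F)F)c1`, in a functional assay on SK-MEL-5 cells (Homo sapiens) for inhibition, read by sulforhodamine B assay, with a stated time of 48 h, tested at 10 uM; a lower number here means a stronger effect, a higher number a weaker effect of the compound at the concentration tested: 23.8%
Compound 2, `COc1cc(Cl)cc(-c2nn(-c3cccc(NC(=O)Nc4ccc(Cl)c(C(F)(F)F)c4)c3)cc2-c2ccncc2)c1`, in this assay: -71.2%
Compound 3, `O=C(Nc1cccc(-n2cc(-c3ccncc3)c(-c3cc(O)cc(Cl)c3)n2)c1)c1cc(C(F)(F)F)cc(C(F)(F)F)c1`, in this assay: 64.5%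

Compound 1 and compound 2 differ in a single place, (methyl in place of hydrogen on an oxygen on an aromatic ring). The step of a number 95 percentage points lower from compound 1 to compound 2 (beyond the scatter) is large and lies well beyond the usual scatter of this kind of measurement. Compound 3 carries the same 3-chloro-5-hydroxyphenyl group on a different core; the difference between the two cores is not broken down here. Among the three measured numbers in this assay compound 3 stands highest, with compound 1 nearer to it and compound 2 far below, both gaps beyond the scatter.

Compound 4, `COc1cc(Cl)cc(-c2nn(-c3cccc(NC(=O)c4cc(C(F)(F)F)cc(C(F)(F)F)c4)c3)cc2-c2ccncc2)c1`, has not yet been measured. It differs from compound 3 by methyl in place of hydrogen on an oxygen on an aromatic ring, the same kind of change as that from compound 1 to compound 2, and the surroundings of the place read alike in both cases: an oxygen on an aromatic ring whose other neighbour is an aromatic carbon. For the measured compounds named here, the single precedent points to a downward step of comparable size when the methyl enters. That precedent rests on one pair and on another core, so the expectation is held with wide bounds. The expected step in this assay is a number 84.5 percentage points lower from compound 3 to compound 4 (beyond the scatter), set beside a number 95 percentage points lower from compound 1 to compound 2 (beyond the scatter). For compound 4 the estimate in this assay is -20%, with a range from -80% to 45%.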

Compound 4, a percentage reported as activity, at one concentration (the size of the read-out at that concentration, not a potency): 67.3%
Compound 4: the middle estimate sits 87.3 percentage points below what was measured; the measured number lies above the stated range.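

In this assay, the change from hydroxy to methoxy on the core of compound 3 gives a number 2.8 percentage points higher from compound 3 to compound 4 (within the scatter), so at the concentration tested the two compounds cannot be told apart. The outcome of this one change therefore does not carry from one core to the other in this series: the same change on two cores in this assay, a number 95 percentage points lower (beyond the scatter) from compound 1 to compound 2 and a number 2.8 percentage points higher (within the scatter) from compound 3 to compound 4, 97.8 percentage points apart, beyond the scatter of two such steps What this shows is that the large step seen on the core of compound 1 cannot be taken as a general result of methylating this oxygen; it does not show which part of the difference between the two cores decides the outcome, and with a single pair on each core it cannot say which outcome is the more usual one in the series.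

On these data alone, it remains open whether a longer chain such as ethyl on the same oxygen, or an amine in place of the hydroxy, would behave as on the core of compound 1 or as on the core of compound 3. Also open, as far as these compounds go, is whether the two pairs would still part in this way at other concentrations, since each compound is read here at only one.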